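A few compounds are considered here, and "the series" means these few. Any claim that something is new, unique, unknown or untested is made for them only; others in the source may bear on it.

Compound 1 `CC1(C(=O)NS(=O)(=O)Cc2ccccc2)CCN(c2nc3c(cc2C#N)C(=O)OC3)CC1` gives 6680 nM in a functional assay (Platelet, plasma) for inhibition, with Homo sapiens as the target; a higher number here means a weaker inhibitor, a lower number a stronger inhibitor. Compound 2 `CC1(C(=O)NS(=O)(=O)Cc2ccc(F)cc2F)CCN(c2nc3c(cc2C#N)C(=O)OC3)CC1` gives 8760 nM. Compound 3 `N#Cc1cc2c(nc1N1CCC(C(=O)NS(=O)(=O)Cc3ccc(Cl)cc3)CC1)COC2=O` gives 4420 nM.

Compound 3 sits alongside compound 1 and compound 2: its gaps to both lie within the usual scatter, so the three cannot be told apart on these numbers. Compound 4 `Cc1ccc(CS(=O)(=O)NC(=O)C2CCN(c3nc4c(cc3C#N)C(=O)OC4)CC2)cc1` differs from compound 3 in one place: methyl in place of chloro on an aromatic carbon. For the measured compounds named here, no measured step swaps these two groups. Going by the values given here, the only step measured on the benzyl ring, a 1.3-fold higher number from compound 1 to compound 2 (0.12 log units; within the scatter), stayed within the scatter, so a change on that ring has so far moved nothing. Compound 4 is therefore expected to stay close to compound 3, with a step of a 1.1-fold higher number from compound 3 to compound 4 (0.05 log units; within the scatter) that is not expected to exceed the scatter. Compound 4 is estimated at 5000 nM, with a range from 2500 nM to 10000 nM.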

Compound 4, half-maximal inhibitory concentration: 4280 nM
Compound 4: the middle estimate sits 1.2-fold (0.07 log units) above what was measured; the range from low to high includes it.
By their numbers in this assay, from the lowest: compounds 4, 3, 1 and 2 (each within the scatter of the next, the first and the last beyond it).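

At the aromatic carbon para to a large group, methyl in place of chloro gives a 1.0-fold lower number from compound 3 to compound 4 (0.01 log units; within the scatter) in this assay, so these two groups cannot be told apart here. Alongside the 2,4-difluorophenyl change, a 1.3-fold higher number from compound 1 to compound 2 (0.12 log units; within the scatter), this means that no change on this ring shown so far goes beyond the scatter. No evidence bears on why the two groups match. On these data alone, whether an amine or a carboxylic acid at this position would give a step beyond the scatter remains open, as does the effect of a longer chain there.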